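This account rests on a few compounds, and the source may have more. Where it says the series, first, only, none or still open, it means among the compounds named here.

Measured so far:
Compound 1 `CCOc1ccccc1-n1nncc1CN1C(=O)C2(C(C#N)=C(N)Oc3c2c2nc4ccccc4nc2c2ccccc32)c2ccccc21`. In a functional assay on HCT-116 cells (Homo sapiens) for antiproliferative activity, read by MTT assay, with a stated time of 48 h (on this read-out lower numbers stand for stronger inhibition and higher numbers for weaker inhibition), compound 1 gives > 50000 nM, which is a limit of the assay and not a number.
Compound 2 `CCOc1ccc(-n2nncc2CN2C(=O)C3(C(C#N)=C(N)Oc4c3c3nc5ccccc5nc3c3ccccc43)c3ccccc32)cc1`. In this assay compound 2 gives > 50000 nM, again only a limit.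
Compound 3 `CCOc1ccc(-n2nncc2CN2C(=O)C3(C(C#N)=C(N)Oc4c(N)cc5nc6ccccc6nc5c43)c3ccccc32)cc1`. In this assay compound 3 gives > 50000 nM, also a limit.

Compound 2 and compound 1 differ in a single place: 2-ethoxyphenyl in place of 4-ethoxyphenyl on an aromatic nitrogen. The step that the two limits leave unreadable from compound 2 to compound 1 cannot be sized, because the limit of > 50000 nM in this assay, at which 3 of the 3 values shown sit, and both ends of the step are therefore hidden behind it.

The same change is now applied to compound 3, giving the unmeasured compound 4 `CCOc1ccccc1-n1nncc1CN1C(=O)C2(C(C#N)=C(N)Oc3c(N)cc4nc5ccccc5nc4c32)c2ccccc21`: 2-ethoxyphenyl in place of 4-ethoxyphenyl on an aromatic nitrogen. The surroundings of the change are the same in both pairs, so this is the same change. How the core of compound 3 differs from that of compound 2 is not broken down here.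

The step from compound 3 to compound 4 is expected to be a step that the limit leaves unreadable from compound 3 to compound 4, which rests on the fact that compound 1, compound 2 and compound 3 all sit at the limit (the limit of > 50000 nM in this assay, at which 3 of the 3 values shown sit). Compound 4 is therefore expected to give 80000 nM, from 30000 nM to 300000 nM.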

Compound 4, half-maximal inhibitory concentration: > 50000 nM
Compound 4 was reported as a limit (the forecaster's own chance of this, stated with the estimate: 85%); the middle value lies beyond the limit too.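

Compound 4 also sits at a limit, so neither the step from compound 3 to compound 4 nor the one from compound 2 to compound 1 can be read, because both ends of each are hidden: the limit of > 50000 nM in this assay, at which 4 of the 4 values shown sit.

The compounds shown leave open whether moving the ethoxy group from 4-ethoxyphenyl to 2-ethoxyphenyl changes activity in this assay at all.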